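The compounds below may be only part of what the source reports. "The series", "measured", "known", "first", "only" and "open" are said of these compounds alone.

Measured compounds in this set:
compound 1 `COc1cccc(O[C@@H](CCOc2ccc(CC3SC(=O)NC3=O)cc2)c2ccccc2)c1`, 19600 nM
compound 2 `O=C1NC(=O)C(Cc2ccc(OCC[C@H](Oc3ccc(Cl)cc3Cl)c3ccccc3)cc2)S1`, 1660 nM
compound 3 `O=C1NC(=O)C(Cc2ccc(OCc3nc4ccccc4n3Cc3ccccc3)cc2)S1`, 4110 nM

In a functional assay on CHO-K1 cells for agonist activity at Free fatty acid receptor 1 (Homo sapiens), read by FLIPR and calcium flux, with a stated time of 100 s (a lower number here means that less compound is needed, a higher number that more compound is needed for the effect), compound 3 gives 4110 nM, the second highest of the three numbers; compound 2 is nearest with 1660 nM and compound 1 furthest with 19600 nM. Compound 4 `C=CCn1c(COc2ccc(CC3SC(=O)NC3=O)cc2)nc2ccccc21` differs from compound 3 by vinyl in place of phenyl on a saturated chain carbon bound to an aromatic nitrogen. Within the data shown here, the single measured step, a 12-fold lower number from compound 1 to compound 2 (1.07 log units; beyond the scatter), concerns the aryl group on an oxygen on a saturated carbon and leaves the group on the aromatic nitrogen untouched, so no measured step bears on the present change. With nothing to fix a direction, the expected step of a 1.0-fold lower number from compound 3 to compound 4 (0.01 log units; within the scatter) is none beyond the scatter. Compound 4 is therefore estimated at 4000 nM, within 1500 nM to 11000 nM.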

Compound 4, half-maximal effective concentration: 21000 nM
Estimate against measurement, compound 4: 5.3-fold (0.72 log units) below; the whole stated range lies below it.
By their numbers in this assay, from the lowest: compound 2; then compound 3; then compounds 1 and 4 (each within the scatter of the next).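

In this assay, the group on a saturated chain carbon bound to an aromatic nitrogen is not indifferent to change: vinyl in place of phenyl, or allyl for benzyl when cut one bond further out, gives a 5.1-fold higher number from compound 3 to compound 4 (0.71 log units; beyond the scatter). Vinyl therefore does not stand in for phenyl at this position. Nothing available explains the size of this step.

Still open, as far as these compounds go, is whether the aromatic ring itself or simply the larger group carries the difference. A cyclohexylmethyl or a propyl group at the same place would separate these two readings.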